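Benzyl ether substituent swaps on a shared core

The source may hold more compounds than are shown below. What is called first, only, known or untested is meant among the compounds shown, and "the series" means these compounds.

Compound 1 `Cc1ccccc1COc1ccc(-c2cc(CN3CCN(Cc4ccc(C(F)(F)F)cc4)CC3)no2)cc1` gives 6800 nM in a functional assay on Mahlavu cells (Homo sapiens) for antiproliferative activity, read by sulforhodamine B assay, with a stated time of 72 h; a higher number here means a weaker inhibitor, a lower number a stronger inhibitor.
Compound 2 `FC(F)(F)c1ccc(CN2CCN(Cc3cc(-c4ccc(OCc5ccccc5Cl)cc4)on3)CC2)cc1` gives 3200 nM in this assay.
Compound 3 `N#Cc1ccccc1COc1ccc(-c2cc(CN3CCN(Cc4ccc(C(F)(F)F)cc4)CC3)no2)cc1` gives 3500 nM in this assay.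

Compound 2 has the lowest number of the three: the step of a 2.1-fold lower number from compound 1 to compound 2 (0.33 log units; beyond the scatter) lies beyond the scatter, whereas the step of a 1.1-fold higher number from compound 2 to compound 3 (0.04 log units; within the scatter) lies within it, so compound 2 and compound 3 cannot be ordered. Compound 4 `Fc1ccc(COc2ccc(-c3cc(CN4CCN(Cc5ccc(C(F)(F)F)cc5)CC4)no3)cc2)cc1` differs from compound 2 by 4-fluorophenyl in place of 2-chlorophenyl on a saturated chain carbon bound to an oxygen on an aromatic ring. Within the data shown here, no measured step exchanges a halogen-bearing ring at a different position; the steps that exist only swap groups at one place, namely a 2.1-fold lower number from compound 1 to compound 2 (0.33 log units; beyond the scatter), a 1.9-fold lower number from compound 1 to compound 3 (0.29 log units; within the scatter) and a 1.1-fold higher number from compound 2 to compound 3 (0.04 log units; within the scatter), all modest or within the scatter. Compound 4 is therefore expected to stay close to compound 2, with a 1.4-fold higher number from compound 2 to compound 4 (0.15 log units; within the scatter) likely small. The estimate for compound 4 is 4500 nM, ranging from 2000 nM to 10000 nM.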

Compound 4, half-maximal inhibitory concentration: 3100 nM
Estimate against measurement, compound 4: 1.5-fold (0.16 log units) above, within the range that was stated.
By their numbers in this assay, from the lowest: compounds 4, 2, 3 and 1 (each within the scatter of the next, the first and the last beyond it).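

In this assay the steps of a 1.0-fold lower number from compound 2 to compound 4 (0.01 log units; within the scatter) and a 1.1-fold lower number from compound 3 to compound 4 (0.05 log units; within the scatter) both lie within the scatter, so at this place 4-fluorophenyl cannot be told apart from 2-chlorophenyl or 2-cyanophenyl. Only a 2.2-fold lower number from compound 1 to compound 4 (0.34 log units; beyond the scatter) lies beyond it, a modest step, which sets 4-fluorophenyl apart from 2-methylphenyl. Nothing measured here explains these steps.

Going by these compounds, whether an amine or a carboxylic acid on this ring would shift the number stays open. Also open, on these data alone, is how much the halogen and its place each count, as both change together from 2-chlorophenyl to 4-fluorophenyl.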